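Pyridin-4-yl to methoxy on the shared core

The source may hold more compounds than are shown below. What is called first, only, known or untested is meant among the compounds shown, and "the series" means these compounds.

Measured so far in a functional assay on MDA-MB-231 cells (Homo sapiens) for inhibition, read by MTT assay, with a stated time of 72 h; a lower number here means a stronger inhibitor, a higher number a weaker inhibitor
compound 1 `COc1ccc(-c2cc(C(=O)N3CCC4(CC3)CC(=O)c3nn(C(C)(C)C)cc3O4)c3ccccc3n2)cc1` gives > 10000 nM
compound 2 `CN(C)c1ccc(-c2cc(C(=O)N3CCC4(CC3)CC(=O)c3nn(C(C)(C)C)cc3O4)c3ccccc3n2)cc1` gives > 10000 nM
compound 3 `CC(C)(C)n1cc2c(n1)C(=O)CC1(CCN(C(=O)c3cc(-c4ccncc4)nc4ccccc34)CC1)O2` gives 1650 nM

Compound 1 stands at > 10000 nM as a limit of the assay and not a number. Compound 2 stands at > 10000 nM as a limit too. Among the compounds with values here, compound 3 stands at 1650 nM and holds the only number of the three. The two steps into it are an at least 6.0-fold lower number from compound 1 to compound 3 (0.78 log units; beyond the scatter) and an at least 6.0-fold lower number from compound 2 to compound 3 (0.78 log units; beyond the scatter) and both lie beyond the scatter. The remaining pair shows a step that the two limits leave unreadable from compound 1 to compound 2 and adds no size.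

Compound 4 `COc1cc(C(=O)N2CCC3(CC2)CC(=O)c2nn(C(C)(C)C)cc2O3)c2ccccc2n1` keeps the core of compound 3 and carries methoxy in place of pyridin-4-yl on an aromatic carbon, next to the ring nitrogen (methoxy in place of pyridin-4-yl on an aromatic carbon). Within the data shown here, no measured compound has a group without a ring at this carbon, so the evidence is indirect. Only compound 3 at 1650 nM gives a number with the group changed here, and compound 4 loses that pyridin-4-yl. A modest step towards a higher number is therefore expected in this assay and it may run into the limit. The estimate means a 3.0-fold higher number from compound 3 to compound 4 (0.48 log units; beyond the scatter) as an expected change. For compound 4 the estimated value is 5000 nM with an expected range from 1500 nM to 16000 nM and a real chance of ending at the limit of the assay.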

Compound 4, half-maximal inhibitory concentration: > 10000 nM
Compound 4: no number, only a limit; the forecaster's own chance of this, stated with the estimate: 45%; at least 2.0-fold (0.30 log units) between middle value and limit.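

In this assay, methoxy in place of pyridin-4-yl on this aromatic carbon, next to the ring nitrogen, gives an at least 6.0-fold higher number from compound 3 to compound 4 (0.78 log units; beyond the scatter), so this small group without a ring does not retain the measurable inhibition of compound 3. Within the data shown here, the earlier compounds varied only the ring carried at this carbon, whereas compound 4 removes the ring and still gives no number, which leaves pyridin-4-yl as the only group of the four with a measured value. Compound 4 stands at a limit of the assay and not at a number, and its steps from compound 1 and compound 2 cannot be read because both ends of each step are limits: the limit of > 10000 nM in this assay, at which 3 of the 4 values shown sit.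

Going by these compounds, how methoxy, 4-methoxyphenyl and 4-(dimethylamino)phenyl rank against one another stays open, as does how far compound 4 lies from compound 3 beyond the printed minimum. On these data alone, it is also open whether the activity depends on the ring nitrogen of pyridin-4-yl or on having a ring here at all, a question that an unsubstituted phenyl, a pyrimidine ring or a morpholine at this carbon would address.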